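Silyl ether for fluorine on the methoxyphenyl arm

The source may report more compounds than this note shows. Statements on the series, on what has been measured and on what is new or still open speak of the compounds shown alone.

Measured so far:
compound 1, `COc1ccc(/C=C(/C(=O)c2cc(OC)c(OC)c(OC)c2)c2ccccc2O)cc1F`: 60000 nM
compound 2, `COc1ccc(C=C(C(=O)c2cc(OC)c(OC)c(OC)c2)c2ccc(C)cc2)cc1[N+](=O)[O-]`: 2430000 nM

In a functional assay on K562 cells (Homo sapiens) for antiproliferative activity, read by MTT assay, with a stated time of 5 days (a lower number here means a stronger inhibitor, a higher number a weaker inhibitor), compound 1 gives 60000 nM, the lower of the two numbers recorded. Compound 2 gives 2430000 nM, and the gap between compound 1 and compound 2 lies beyond the scatter, so compound 1 is the stronger inhibitor of the two measured. For the measured compounds named here, both values are weak, and no single-point step between measured compounds exists to calibrate the series.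

Compound 3 is `COc1ccc(/C=C(/C(=O)c2cc(OC)c(OC)c(OC)c2)c2ccccc2O)cc1O[Si](C)(C)C(C)(C)C`. It differs from compound 1 by a group of 8 heavy atoms (6 carbon, 1 oxygen, 1 silicon; no ring) in place of one fluorine atom, on an aromatic carbon. Going by the values given here, the entering group is large and carries silicon, and nothing among the measured compounds shows how such a group is tolerated at this position. Among the compounds with values here, with compound 1 already weak and no comparable step to lean on, the step in this assay from compound 1 to compound 3 is expected to be small or to run toward a weaker inhibitor, most likely within or just beyond the scatter, a 1.7-fold higher number from compound 1 to compound 3 (0.22 log units; within the scatter). Compound 3 is therefore estimated at 100000 nM, with a range of 25000 nM to 400000 nM.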

Compound 3, half-maximal inhibitory concentration: 380000 nM
Compound 3: the middle estimate sits 3.8-fold (0.58 log units) below what was measured; measured number inside the range.
By their numbers in this assay, from the lowest: compound 1; then compound 3; then compound 2.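

In this assay this position now has its first readable step: putting the silyl ether group of 8 heavy atoms in place of fluoro, on the aromatic carbon ortho to a methoxy group, gives a 6.3-fold higher number from compound 1 to compound 3 (0.80 log units; beyond the scatter) and so a modest move toward a weaker inhibitor, beyond the scatter. The position is therefore not indifferent to what it carries, although a much larger entering group costs only a modest step, from a starting point that was already weak. No evidence bearing on the cause of this step is available.

A single step changes size, atom content and the oxygen link at once, and the compounds shown do not separate these. An amine or a chlorine atom on this aromatic carbon, or a plain longer carbon chain joined through the same oxygen, would show whether the higher number follows the size of the silyl ether group, the presence of silicon, or simply the loss of fluoro.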